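The compounds below may be only part of what the source reports. "The series", "measured", "known", "first", "only" and "open" are said of these compounds alone.

In a functional assay on KYSE-410 cells (Homo sapiens) for antiproliferative activity, read by MTT assay, with a stated time of 72 h (on this read-out higher numbers stand for weaker inhibition and lower numbers for stronger inhibition), the series has produced no number yet. Compound 1 (`O=C(Nc1ccc(F)cc1F)c1cc(=O)[nH]c2cc(Br)ccc12`) is a limit, > 20000 nM. Compound 2 (`O=C(Nc1cccc(F)c1)c1cc(=O)[nH]c2cc(F)ccc12`) is also only a limit, > 20000 nM. Compound 3 (`O=C(Nc1cc(F)cc(F)c1)c1cc(=O)[nH]c2cc(F)ccc12`) is a limit as well, > 20000 nM. The whole picture so far is the limit of > 20000 nM in this assay, at which 3 of the 3 values shown sit.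

Compound 4 (`O=C(Nc1cccc(F)c1)c1cc(=O)[nH]c2cc(-c3ccc(F)cc3)ccc12`) differs from compound 2 by 4-fluorophenyl in place of fluoro on an aromatic carbon, with 4-fluorophenyl in place of fluoro on an aromatic carbon. Among the measured compounds shown here, the only measured step, a step that the two limits leave unreadable from compound 2 to compound 3, is fluoro in place of hydrogen and offers no size to carry over. With no readable guide, a number in this assay could appear only on the side of stronger inhibition. The expected step, an at least 1.6-fold lower number from compound 2 to compound 4 (0.22 log units; that floor lies within the scatter), is small and remains a rough estimate. For compound 4 the estimated value is 12000 nM, with an expected range of 2500 nM to 20000 nM.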

Compound 4, half-maximal inhibitory concentration: 10300 nM
The estimate for compound 4 lay 1.2-fold (0.07 log units) above the measured number, and the stated range covers the measured number.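

Among the compounds shown here, replacing fluoro with 4-fluorophenyl on this aromatic carbon of the core gives the first measured number in this assay, an at least 1.9-fold lower number from compound 2 to compound 4 (0.28 log units; that floor lies within the scatter). Compound 2 is only a limit, so this step gives a floor and not a size, and that floor does not establish a change beyond the scatter. Compound 4 is thus the only readable point so far, and the rest of the series remains at the limit: the limit of > 20000 nM in this assay, at which 3 of the 4 values shown sit.

From the compounds shown here alone, it remains open whether the number depends on the fluorine of the added ring. An unsubstituted phenyl, a methoxy group or an amine at this position could settle how much the ring itself contributes.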